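Amide group changes on the shared core

The compounds below may be only part of what the source reports. "The series", "measured", "known", "first", "only" and "open" are said of these compounds alone.

Values below come from an assay on HEK293 cells for positive allosteric modulation of metabotropic glutamate receptor 5 (Homo sapiens), read by FLIPR, with a stated time of 1 h; a lower number here means that less compound is needed, a higher number that more compound is needed for the effect.

compound 1 `O=C(C1CC12CCC2)N1CCc2nc(C#Cc3ccccc3)sc2C1`: 3.9 nM
compound 2 `CC1CCC(C(=O)N2CCc3nc(C#Cc4ccccc4)sc3C2)CC1`: 190 nM
compound 3 `CC1CCCC(C(=O)N2CCc3nc(C#Cc4ccccc4)sc3C2)C1`: 100 nM

Compound 3 has the second highest number of the three; the nearest gap is a 1.9-fold lower number from compound 2 to compound 3 (0.28 log units; within the scatter), while compound 1 sits far off, with a 26-fold higher number from compound 1 to compound 3 (1.41 log units; beyond the scatter). Compound 4 `O=C(CC1CCOCC1)N1CCc2nc(C#Cc3ccccc3)sc2C1` carries (oxan-4-yl)methyl in place of 3-methylcyclohexyl on a carbonyl carbon. Among the measured compounds shown here, no measured step exchanges a carbon ring for a ring with a hetero atom at this position, so only the general picture applies: the large steps of a 49-fold higher number from compound 1 to compound 2 (1.69 log units; beyond the scatter) and a 26-fold higher number from compound 1 to compound 3 (1.41 log units; beyond the scatter) show that this group moves the number strongly, whereas a 1.9-fold lower number from compound 2 to compound 3 (0.28 log units; within the scatter) is within the scatter. For compound 4 the expectation is a number close to compound 3, estimated at 150 nM with a range of 30 nM to 800 nM, a step of a 1.5-fold higher number from compound 3 to compound 4 (0.18 log units; within the scatter) that is uncertain in direction.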

Compound 4, half-maximal effective concentration: 470 nM
The estimate for compound 4 lay 3.1-fold (0.50 log units) below the measured number; the measured number falls inside the stated range.
By their numbers in this assay, from the lowest: compound 1; then compounds 3 and 2 (each within the scatter of the next); then compound 4.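

(Oxan-4-yl)methyl on the carbonyl carbon gives a step beyond the scatter from both methylcyclohexyl groups, with a 4.7-fold higher number from compound 3 to compound 4 (0.67 log units; beyond the scatter) and a 2.5-fold higher number from compound 2 to compound 4 (0.39 log units; beyond the scatter) even though those two groups lie within the scatter of each other. The group of compound 1 remains far ahead, with a 120-fold higher number from compound 1 to compound 4 (2.08 log units; beyond the scatter) as the widest step yet seen at this position. No available data bear on why the number rises.

Compound 4 alters both the ring atoms and the attachment to the carbonyl carbon, so the contribution of each remains unresolved. Cyclohexylmethyl or oxan-4-yl directly on the carbonyl carbon would separate the two.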